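A few compounds are considered here, and "the series" means these few. Any claim that something is new, unique, unknown or untested is made for them only; others in the source may bear on it.

Of the compounds shown here, three that share one core have been measured in a functional assay (aorta) with Rattus norvegicus as the target; on this read-out lower numbers stand for stronger inhibition and higher numbers for weaker inhibition. Compound 1 `CCOC(=O)c1cnnn1CCOCC1=NC(C)=C(C(=O)OC)C(c2ccccc2Cl)/C1=C(\O)OCC` gives 100 nM. Compound 2 `CCO/C(O)=C1\C(COCCN2CC(=O)NC2=O)=NC(C)=C(C(=O)OC)C1c1ccccc1Cl` gives 20 nM. Compound 3 `CCOC(=O)c1cn(CCOCC2=NC(C)=C(C(=O)OC)C(c3ccccc3Cl)/C2=C(\O)OCC)nn1` gives 50.1 nM. Among the three numbers compound 3 stands second highest; the nearest is compound 1, with a 2.0-fold lower number from compound 1 to compound 3 (0.30 log units; within the scatter), and the furthest is compound 2, with a 2.5-fold higher number from compound 2 to compound 3 (0.40 log units; beyond the scatter).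

Compound 4 `CCO/C(O)=C1\C(COCCn2c(C)nc(C)c2C)=NC(C)=C(C(=O)OC)C1c1ccccc1Cl` has not yet been measured. It differs from compound 3 in one place: 2,4,5-trimethyl-1H-imidazol-1-yl in place of 4-(ethoxycarbonyl)-1H-1,2,3-triazol-1-yl on a saturated chain carbon, two bonds along the chain from an oxygen on a saturated carbon. All three measured steps concern a change of the ring at this same place, so all bear on it. Exchanging the 5-(ethoxycarbonyl)-1H-1,2,3-triazol-1-yl ring for 2,4-dioxoimidazolidin-1-yl gave a 5.0-fold lower number from compound 1 to compound 2 (0.70 log units; beyond the scatter), whereas exchanging it for the 4-(ethoxycarbonyl) counterpart gave a 2.0-fold lower number from compound 1 to compound 3 (0.30 log units; within the scatter). Swapping the ring at this place has thus shifted the read-out in this assay by at most modest amounts, in both directions. Among the measured compounds shown here, no measured compound carries the 2,4,5-trimethyl-1H-imidazol-1-yl ring, so no direction can be read from the data, and only a modest step, if any, is expected. For compound 4 the expected step is a 1.0-fold lower number from compound 3 to compound 4 (0.00 log units; within the scatter). Compound 4 is therefore estimated at 50 nM, with a range from 15 nM to 160 nM.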

Compound 4, half-maximal inhibitory concentration: 5.01 nM
For compound 4 the middle estimate is 10-fold (1.00 log units) above the measured one; the measured number lies below the stated range.
By their numbers in this assay, from the lowest: compound 4; then compound 2; then compounds 3 and 1 (each within the scatter of the next).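

In this assay, the ring at the end of this chain turns out to matter more than the first three compounds suggested: 2,4,5-trimethyl-1H-imidazol-1-yl gives a clear drop against the 4-(ethoxycarbonyl)-1H-1,2,3-triazol-1-yl ring (a 10-fold lower number from compound 3 to compound 4 (1.00 log units; beyond the scatter)), against the 2,4-dioxoimidazolidin-1-yl ring (a 4.0-fold lower number from compound 2 to compound 4 (0.60 log units; beyond the scatter)) and against the 5-(ethoxycarbonyl)-1H-1,2,3-triazol-1-yl ring (a 20-fold lower number from compound 1 to compound 4 (1.30 log units; beyond the scatter)). Among the compounds shown here, the last of these is larger than any step among the earlier compounds, and all three lie beyond the scatter, so compound 4 is the most potent of the four. Compared with compound 3, the entering ring has 2 hydrogen-bond acceptors in place of 5 and no ethoxycarbonyl group, but no measurement shown here accounts for the drop.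

The compounds shown leave open whether the gain comes from the three methyl groups or from the ring itself, a question that a plain 1H-imidazol-1-yl ring without methyl groups could help to separate. They also leave open how a simple dimethylamino group at this place, or a longer chain leading to the same ring, would read in this assay.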